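Aryl for butyl on the core: the methoxy variant

The source may hold more compounds than are shown below. What is called first, only, known or untested is meant among the compounds shown, and "the series" means these compounds.

Measured so far in a functional assay on MIA PaCa-2 cells (Homo sapiens) for antiproliferative activity, read by MTT assay, with a stated time of 48 h; on this read-out lower numbers stand for stronger inhibition and higher numbers for weaker inhibition:
compound 1 `CCCCCc1nc(N)n(CC(=O)Nc2ccccc2)c1-c1ccccc1Br`: 40600 nM
compound 2 `Nc1nc(Cc2ccccc2)c(-c2ccccc2Br)n1CC(=O)Nc1ccccc1`: 5700 nM
compound 3 `Cc1ccc(Cc2nc(N)n(CC(=O)Nc3ccccc3)c2-c2ccccc2Br)cc1`: 9200 nM

Compound 1 stands highest of the three numbers in this assay; its nearest neighbour is compound 3 and the furthest is compound 2, both steps beyond the scatter.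

Compound 4 `COc1ccc(Cc2nc(N)n(CC(=O)Nc3ccccc3)c2-c2ccccc2Br)cc1` is not yet measured. It differs from compound 1 by 4-methoxyphenyl in place of butyl on a saturated chain carbon bound to an aromatic carbon.

Going by the values given here, two measured steps bear directly on this change. Replacing butyl by phenyl gave a 7.1-fold lower number from compound 1 to compound 2 (0.85 log units; beyond the scatter), and replacing butyl by 4-methylphenyl gave a 4.4-fold lower number from compound 1 to compound 3 (0.64 log units; beyond the scatter). The two aryl variants differ by a 1.6-fold higher number from compound 2 to compound 3 (0.21 log units; within the scatter), which is within the scatter, so the substituent on the entering ring has so far not shifted the number beyond noise.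

Compound 4 is therefore expected to fall with compounds 2 and 3 rather than with compound 1, a step of about a 5.8-fold lower number from compound 1 to compound 4 (0.76 log units; beyond the scatter) in this assay. The estimate for compound 4 is 7000 nM, with a range from 2500 nM to 20000 nM.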

Compound 4, half-maximal inhibitory concentration: 3200 nM
The estimate for compound 4 lay 2.2-fold (0.34 log units) above the measured number; measured number inside the range.
By their numbers in this assay, from the lowest: compounds 4, 2 and 3 (each within the scatter of the next, the first and the last beyond it); then compound 1.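

In this assay, 4-methoxyphenyl in place of butyl on a saturated chain carbon bound to an aromatic carbon gives (a 13-fold lower number from compound 1 to compound 4 (1.10 log units; beyond the scatter)), so three aryl groups now lie beyond the scatter from butyl at this position. The substituent on the entering ring can now shift the number: methoxy in place of methyl gives (a 2.9-fold lower number from compound 3 to compound 4 (0.46 log units; beyond the scatter)), beyond the scatter, although methoxy in place of hydrogen gives (a 1.8-fold lower number from compound 2 to compound 4 (0.25 log units; within the scatter)), within it, so only the methoxy and methyl variants separate. Nothing available accounts for this separation or for the aryl-for-butyl steps.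

Open, on these data alone, is whether a hydroxy group or a chlorine on the entering ring would sit with methoxy or with methyl. Also open, as far as these compounds go, is whether cyclohexyl in place of butyl would match the aryl groups or stay with butyl.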